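Notes on the step from compound 2 to compound 4

The compounds below may be only part of what the source reports. "The series", "measured", "known", "first", "only" and "open" are said of these compounds alone.

The series is read in a functional assay on the whole organism (aorta) with Rattus norvegicus as the target; a higher number here means a larger maximal response, a lower number a smaller maximal response. Compound 1 `O=C1C=CC(=O)c2cnccc21` gives 92%. Compound 2 `O=C1C(Nc2ccc(F)cc2)=CC(=O)c2ncccc21` gives 79%, and compound 3 `O=C1C(Nc2ccc(F)c(F)c2)=CC(=O)c2ncccc21` gives 92%. Compound 2 stands lowest of the three; compound 1 and compound 3 each sit above it by a margin beyond the scatter. Going by the values given here, the one step between measured compounds that differ in a single place is a number 13 percentage points higher from compound 2 to compound 3 (beyond the scatter).

Compound 4 `O=C1C(Nc2ccc(I)cc2)=CC(=O)c2ncccc21` differs from compound 2 in one place: iodo in place of fluoro on an aromatic carbon. Among the compounds with values here, no measured pair in the set exchanges one halogen for another, so the step from compound 2 to compound 3 bears only loosely on the present change: it adds a fluoro where hydrogen stood, and a modest gain accompanied it. Within the data shown here, the present change keeps a halogen on that ring and swaps it for a heavier one, for which the set gives no precedent. On that basis no step beyond the scatter, or at most a small rise, is expected in this assay for compound 4. The estimate for compound 4 is 85%, with a range from 72% to 97%. The step this estimate implies is a number 6 percentage points higher from compound 2 to compound 4 (within the scatter), expected to stay within the scatter.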

Compound 4, largest response reached (Emax), in percent of the reference or control that the assay uses: 89%
Compound 4: the middle estimate sits 4 percentage points below what was measured; low and high end bracket the measured number.
By their numbers in this assay, from the lowest: compounds 2, 4, 1 and 3 (each within the scatter of the next, the first and the last beyond it).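

Going by these compounds alone, the exchange of fluoro for iodo on an aromatic carbon para to a large group is the first halogen-for-halogen pair. In this assay, within the data shown here, it reads as a number 10 percentage points higher from compound 2 to compound 4 (within the scatter) and shows that this position accepts iodo in place of fluoro with no step beyond the scatter, whereas the only earlier single-place step, a number 13 percentage points higher from compound 2 to compound 3 (beyond the scatter), concerned a fluoro entering where hydrogen stood and said nothing about exchanging the halogen already present. No measured evidence accompanies this pair to account for the reading.

The compounds shown leave open how far this tolerance extends at the same place, since chloro and bromo, as the halogens lying between fluoro and iodo, and non-halogen groups such as methoxy, an amine or a carboxylic acid do not appear there. Also open, going by these compounds, is whether iodo on that ring would read differently with a second halogen alongside it in the pattern of compound 3, and whether the series would keep its present reading in this assay with such a pairing.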